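This account rests on a few compounds, and the source may have more. Where it says the series, first, only, none or still open, it means among the compounds named here.

Of the compounds shown here, three built on one shared core have been tested in an assay on HEK293 cells for positive allosteric modulation of metabotropic glutamate receptor 2 (Rattus norvegicus), read by thallium flux, with a stated time of 2.5 min; a lower number here means a smaller maximal response, a higher number a larger maximal response. Compound 1 `COC(=O)c1ccc(OCCCCOc2ccc(C(=O)CC3CCCC3)c(O)c2C)cc1` gives 12.2%. Compound 2 `CCCC(=O)c1ccc(OCCCCOc2ccc(F)c(C(=O)O)c2)c(C)c1O` gives 87.5%, and compound 3 `Cc1cc(C(=O)O)ccc1OCCCCOc1ccc(C(=O)C(C)C)c(O)c1C` gives 76.9%. Among these three numbers compound 2 stands highest. Compound 3 comes nearest, with a number lower by a margin that lies beyond the usual scatter, while compound 1 lies furthest away, with a far smaller maximal response.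

Compound 4 `CC(=O)c1ccc(OCCCCOc2ccc(F)c(C(=O)O)c2)c(C)c1O` has not yet been measured. It differs from compound 2 in a single place: hydrogen in place of ethyl on a saturated chain carbon bound to a carbonyl carbon. Among the measured compounds shown here, no step between two measured compounds shows this same change, so nothing in the data tells directly how much the maximal response moves when the chain on the carbonyl is shortened in this way. For the measured compounds named here, what is known is only that compound 2 already reaches a high maximal response in this assay, and that the one change here removes a short chain without touching any ring or any hydrogen-bond donor or acceptor.

The step of a number 9.5 percentage points lower from compound 2 to compound 4 (within the scatter) is therefore expected to be small, possibly within the scatter, and if anything pointing downward rather than upward. For compound 4 the estimated maximal response is 78%, with a likely range from 55% to 95%.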

Compound 4, largest response reached (reported as percent of maximum), in percent of the reference or control that the assay uses: 75.5%
Beside the measured number, compound 4's estimate is 2.5 percentage points above it; the measured number falls inside the stated range.
By their numbers in this assay, from the lowest: compound 1; then compounds 4 and 3 (each within the scatter of the next); then compound 2.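

In this assay, hydrogen in place of ethyl on a saturated chain carbon bound to a carbonyl carbon, which turns the propylcarbonyl group into acetyl, gives a number 12 percentage points lower from compound 2 to compound 4 (beyond the scatter). Among the compounds shown here, this is the first direct reading of this position, since no earlier pair of compounds differed only here, and it shows that the length of this chain does affect the maximal response, though the step is modest: even with only the acetyl group left, compound 4 still gives 75.5%. The data shown offer no measured explanation for this step.

With only the propyl and methyl ends compared on an otherwise unchanged structure, this single pair gives a direction for one change and does not establish a trend with chain length. On these data alone, whether a longer chain such as pentyl would raise the maximal response, hold it level or lower it remains open, as does the effect of placing an amine or a hydroxyl group on this chain.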